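Chloro to methyl on the fused ring: exposure expectation

The source may report more compounds than this note shows. Statements on the series, on what has been measured and on what is new or still open speak of the compounds shown alone.

Two compounds of the series have plasma exposure numbers. Compound 1 `Cc1cc2c(-c3ccc[nH]c3=O)c(C(=O)NS(=O)(=O)C3CC3)n(Cc3cc([N+](=O)[O-])ccc3F)c2cc1F` carries a methyl and a fluoro on its fused ring; in an ADME assay on the whole organism (plasma) for pharmacokinetics, with Rattus norvegicus as the target, at a dose of 10 mg/kg by the oral route (on this read-out lower numbers stand for lower exposure and higher numbers for higher exposure at the dose given), compound 1 gives 190 ng.h/mL. Compound 2 `O=C(NS(=O)(=O)C1CC1)c1c(-c2ccc[nH]c2=O)c2cc(Cl)ccc2n1Cc1cc([N+](=O)[O-])ccc1F` carries a chloro there instead; in this assay compound 2 gives 163 ng.h/mL. Compound 2 stands at the lower of the two numbers, but its gap to compound 1 lies within the scatter, so the two values show no readable difference. Compound 3 `Cc1ccc2c(c1)c(-c1ccc[nH]c1=O)c(C(=O)NS(=O)(=O)C1CC1)n2Cc1cc([N+](=O)[O-])ccc1F` has not yet been run in this assay. It differs from compound 2 by methyl in place of chloro on an aromatic carbon. Going by the values given here, no pair of measured compounds isolates this change. Resting on compounds 1 and 2 alone, the step from compound 2 to compound 3 is expected to be a 1.1-fold higher number from compound 2 to compound 3 (0.03 log units; within the scatter), nothing beyond the scatter. Compound 3 is therefore estimated at 175 ng.h/mL, within 80 ng.h/mL to 400 ng.h/mL.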

Compound 3, area under the concentration-time curve: 5.25 ng.h/mL
Beside the measured number, compound 3's estimate is 33-fold (1.52 log units) above it; measured number outside the range, below it.
By their numbers in this assay, from the lowest: compound 3; then compounds 2 and 1 (each within the scatter of the next).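

In this assay, methyl does not stand in for chloro on this aromatic carbon: a 31-fold lower number from compound 2 to compound 3 (1.49 log units; beyond the scatter) is a large step for the exchange of one heavy atom for another. Hydrogen in place of fluoro on an aromatic carbon of the same ring also gives a large step, a 36-fold lower number from compound 1 to compound 3 (1.56 log units; beyond the scatter), so the two compounds with a halogen on this ring both sit far above compound 3, the only one of the three without one. Nothing available explains this loss of exposure.

As far as these compounds go, it remains open whether a halogen on this ring is what matters, or whether a bromo, trifluoromethyl or nitrile group in place of the methyl of compound 3 would also restore exposure. From the compounds shown here alone, the separate contribution of the methyl in compound 1 also remains open.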